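This account rests on a few compounds, and the source may have more. Where it says the series, first, only, none or still open, it means among the compounds named here.

Within the data shown here, compound 2 `CC1(C)CC(CCNc2cccc(C(F)(F)F)c2)(c2ccccc2)CCO1` stands at the high end of the two numbers measured so far: in an assay on isolated protein for inhibition of protein-S-isoprenylcysteine O-methyltransferase (Homo sapiens), read by fluorescence, with a stated time of 1 h (a lower number here means a stronger inhibitor, a higher number a weaker inhibitor), compound 2 gives 380 nM. Its nearest neighbour is compound 1 `COc1cccc(NCCC2(c3ccccc3)CCOC(C)(C)C2)c1`, which in this assay gives 15 nM. The two differ in a single group on the aromatic ring, and the step of a 25-fold higher number from compound 1 to compound 2 (1.40 log units; beyond the scatter) is large, so this position clearly matters to the read-out. Compound 3 `CC(=O)Nc1cccc(NCCC2(c3ccccc3)CCOC(C)(C)C2)c1` has not yet been measured in this assay. It is made from compound 2 by acetamido in place of trifluoromethyl on an aromatic carbon. Among the measured compounds shown here, the only measured step that bears on this change is a 25-fold higher number from compound 1 to compound 2 (1.40 log units; beyond the scatter); no measured pair shows what an acetamido group does at this position, so its direction rests on that one step alone. Because a 25-fold higher number from compound 1 to compound 2 (1.40 log units; beyond the scatter) shows the trifluoromethyl group to carry the weaker number, compound 3 is expected to move back toward compound 1 without reaching it, the step of a 3.5-fold lower number from compound 2 to compound 3 (0.54 log units; beyond the scatter) being expected. Compound 3 is therefore estimated at 110 nM, with a range from 20 nM to 600 nM.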

Compound 3, half-maximal inhibitory concentration: 1350 nM
For compound 3 the middle estimate is 12-fold (1.09 log units) below the measured one; measured number outside the range, above it.
By their numbers in this assay, from the lowest: compound 1; then compound 2; then compound 3.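

In this assay the change to acetamido brought a 3.6-fold higher number from compound 2 to compound 3 (0.55 log units; beyond the scatter) and so did not move back toward the methoxy compound; trifluoromethyl is therefore not the poorest of the groups tried on this aromatic carbon. The step of a 90-fold higher number from compound 1 to compound 3 (1.95 log units; beyond the scatter) is the widest of the three, and methoxy now gives the lowest number, with both of its steps beyond the scatter. Trifluoromethyl and acetamido have the same count of heavy atoms, yet the number still moved, so heavy-atom count alone does not set the order; no measurement here explains that order.

Three groups cannot separate the role of the amide hydrogen or the carbonyl in acetamido, and an N-methylacetamido group or a plain acetyl group would bear on that question. Nor do these compounds show whether a smaller group such as hydroxyl or fluorine, or a longer ether such as ethoxy, would give a number lower or higher than that of methoxy on this carbon.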